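The compounds below may be only part of what the source reports. "The series", "measured", "known", "first", "only" and "open" are said of these compounds alone.

Measured in a functional assay on HeLa cells (Homo sapiens) for inhibition, with a stated time of 48 h, tested at 50 uM; a lower number here means less inhibition of growth, a higher number more inhibition of growth at the concentration tested:
- Compound 1 `C=C[C@@](C)(/C=C/c1ccc(OC(=O)CCCC)cc1)CCC=C(C)C`: 23%
- Compound 2 `COc1ccc(/C=C/[C@@](C)(/C=C/c2ccc(O)cc2)CCC=C(C)C)cc1`: 20%
- Compound 3 `COc1ccc(/C=C/[C@@](C)(/C=C/c2ccc(O)cc2)CCC=C(C)C)cc1C=O`: 31%

In this assay, compound 3 gives 31%. That number lies within the scatter of compound 1 and clearly beyond the scatter of compound 2, so compound 3 shares the top of this small set with compound 1.

The next compound, compound 4 `COc1ccc(/C=C/[C@@](C)(/C=C/c2ccc(O)cc2)CCC=C(C)C)cc1CO`, keeps the core of compound 3 and carries hydroxymethyl in place of formyl on an aromatic carbon, ortho to a methoxy group and meta to a large group (hydroxymethyl in place of formyl on an aromatic carbon).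

Among the measured compounds shown here, only one measured step bears on this change. It is a number 11 percentage points higher from compound 2 to compound 3 (beyond the scatter), which put formyl in place of hydrogen on that same aromatic carbon and was modest but beyond the scatter. For the measured compounds named here, no measured compound carries hydroxymethyl, so the data do not show whether it would behave more like formyl or like hydrogen. A result between compound 2 and compound 3 seems the most reasonable expectation, which means a small fall that stays within the scatter. The expected change is a number 5 percentage points lower from compound 3 to compound 4 (within the scatter).

For compound 4 the estimate is 26%, with an expected range of 15% to 38%.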

Compound 4, percent growth inhibition at one concentration: 36%
Estimate against measurement, compound 4: 10 percentage points below; measured number inside the range.
By their numbers in this assay, from the lowest: compounds 2, 1, 3 and 4 (each within the scatter of the next, the first and the last beyond it).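

In this assay the exchange of formyl for hydroxymethyl on this aromatic carbon, ortho to a methoxy group, gives a number 5 percentage points higher from compound 3 to compound 4 (within the scatter) and so does not separate the two groups, although hydroxymethyl carries a hydrogen-bond donor that formyl lacks. Set against hydrogen on the same carbon, hydroxymethyl gives a number 16 percentage points higher from compound 2 to compound 4 (beyond the scatter) and formyl gives a number 11 percentage points higher from compound 2 to compound 3 (beyond the scatter) so the rise over hydrogen at this position is no longer tied to formyl alone. Nothing available explains why these two groups read alike here or why either stands clear of hydrogen.

Going by these compounds, whether an aminomethyl group, a carboxylic acid or a longer chain ending in hydroxyl on this carbon would stay level with formyl and hydroxymethyl or fall back towards hydrogen remains open. These readings also come from one concentration in one cell line, which leaves open how the compounds would compare across a range of concentrations or in other cells.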